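Adding a Methylphenyl Arm to Compound 3

The compounds below may be only part of what the source reports. "The series", "measured", "known", "first", "only" and "open" are said of these compounds alone.

In a functional assay on MCF7 cells (Homo sapiens) for cytotoxicity, read by MTT assay, with a stated time of 24 h, tested at 1.6 ug/mL (on this read-out higher numbers stand for a stronger effect at the one concentration tested and lower numbers for a weaker effect), compound 3 `CN1CCN(CC(=O)Nc2ccc(-c3nc(-c4ccccc4)c(-c4ccccc4)n3C)cc2)CC1` gives 2.9%, the smallest of the three numbers, although its gap to compound 1 lies within the scatter. Compound 1 `Cn1c(-c2ccc(NC(=O)CCl)cc2)nc(-c2ccccc2)c1-c1ccccc1` gives 4.3%, and the step of a number 1.4 percentage points lower from compound 1 to compound 3 (within the scatter). Compound 2 `Cn1ccnc1SCC(=O)Nc1ccc(-c2nc(-c3ccccc3)c(-c3ccccc3)n2C)cc1` gives 17.5%, and the step of a number 14.6 percentage points lower from compound 2 to compound 3 (beyond the scatter). Compound 4 `Cc1ccc(CN2CCN(CC(=O)Nc3ccc(-c4nc(-c5ccccc5)c(-c5ccccc5)n4C)cc3)CC2)cc1` differs from compound 3 by 4-methylphenyl in place of hydrogen on a saturated chain carbon bound to an amine nitrogen in a ring. Going by the values given here, every measured step, including a number 13.2 percentage points higher from compound 1 to compound 2 (beyond the scatter), alters the group on the chain carbon bound to the carbonyl carbon; none touches the saturated chain carbon bound to an amine nitrogen in a ring, so no measured step bears directly on this change. With no guide, compound 4 is estimated at 6%, between 0% and 20%. The step of a number 3.1 percentage points higher from compound 3 to compound 4 (within the scatter) is therefore expected to stay within the scatter.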

Compound 4, a percentage reported as activity, at one concentration (the size of the read-out at that concentration, not a potency): 19.3%
Estimate against measurement, compound 4: 13.3 percentage points below; low and high end bracket the measured number.
By their numbers in this assay, from the lowest: compounds 3 and 1 (each within the scatter of the next); then compounds 2 and 4 (each within the scatter of the next).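

Replacing hydrogen with 4-methylphenyl on the saturated chain carbon bound to an amine nitrogen in a ring gives a number 16.4 percentage points higher from compound 3 to compound 4 (beyond the scatter) in this assay. Going by these compounds alone, this shows that the read-out also responds to a change at this outer position, which no earlier step touched. No available evidence gives a reason for the rise.

On these data alone, whether the rise needs the ring's methyl remains open, since an unsubstituted phenyl or a 4-chlorophenyl at this position would be needed to separate the two. A single step also cannot show how a longer chain between ring and amine nitrogen would read.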